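Tail variation on the shared core, compound 1 to compound 3

The source may hold more compounds than are shown below. What is called first, only, known or untested is meant among the compounds shown, and "the series" means these compounds.

Measured so far:
compound 1 `COc1ccc(Br)cc1CCc1c(F)cccc1C(=O)/N=C(\N)NCCN1CCCC1` — 190 nM
compound 2 `CCCC/N=C(/N)NC(=O)c1cccc(F)c1CCc1cc(Br)ccc1OC` — 920 nM

In an assay for binding affinity to Melanocortin receptor 4 (Homo sapiens) (a higher number here means a weaker inhibitor, a lower number a stronger inhibitor), compound 1 gives 190 nM, the lower of the two numbers. Compound 2 gives 920 nM in this assay, and the gap between the two lies beyond the usual scatter; the two compounds differ in more than one place, so no single step can be read from that pair.

Compound 3 `COc1ccc(Br)cc1CCc1c(F)cccc1C(=O)/N=C(\N)NCCCN1CCN(C)CC1` is not yet measured. It differs from compound 1 in one place: (4-methylpiperazin-1-yl)methyl in place of pyrrolidin-1-yl on a saturated chain carbon, two bonds along the chain from an amine nitrogen. Going by the values given here, with no single-change step available among the measured compounds, the size of this step is open. The expectation is a modest change, most likely a step of at most moderate size toward a higher number, and quite possibly none beyond the scatter. Compound 3 is therefore estimated at 280 nM in this assay, within a range from 80 nM to 1000 nM, which corresponds to an expected step of a 1.5-fold higher number from compound 1 to compound 3 (0.17 log units; within the scatter).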

Compound 3, inhibition constant: 64 nM
For compound 3 the middle estimate is 4.4-fold (0.64 log units) above the measured one; measured number below the stated range.
By their numbers in this assay, from the lowest: compound 3; then compound 1; then compound 2.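

In this assay, going by these compounds alone, this tail position accepts a larger group and gains from it: (4-methylpiperazin-1-yl)methyl in place of pyrrolidin-1-yl, on a saturated chain carbon two bonds along the chain from an amine nitrogen, gives a 3.0-fold lower number from compound 1 to compound 3 (0.47 log units; beyond the scatter) and provides the first single-change step. Read one bond further out, the change is 2-(pyrrolidin-1-yl)ethyl to 3-(4-methylpiperazin-1-yl)propyl, so chain length and ring change together and the step cannot be divided between them. Nothing at hand speaks to the origin of this step.

Still open, from the compounds shown here alone, is which part carries the step, which a 3-(pyrrolidin-1-yl)propyl or a 2-(4-methylpiperazin-1-yl)ethyl tail would separate. Also open, going by these compounds, is what a morpholine ring or an unsubstituted piperazine would give in the same place.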